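Trimethoxyphenyl pyrazole enones: replacing the aminophenyl ketone

This account rests on a few compounds, and the source may have more. Where it says the series, first, only, none or still open, it means among the compounds named here.

Measured compounds:
compound 1 `COc1cc(-c2cc(/C=C/C(=O)c3ccc(N)cc3)[nH]n2)cc(OC)c1OC`: 79%
compound 2 `COc1ccc(-c2cc(/C=C/C(=O)c3ccc(OC)c(OC)c3)[nH]n2)cc1`: 82%
compound 3 `COc1ccc(-c2cc(/C=C/C(=O)c3ccc(N)cc3)[nH]n2)cc1`: 71%

In a functional assay on ACHN cells (Homo sapiens) for cytotoxicity, read by sulforhodamine B assay, with a stated time of 48 h, tested at 1 uM (a lower number here means a stronger effect, a higher number a weaker effect of the compound at the concentration tested), compound 1 gives 79%. Its number sits in the middle of the three, with compound 2 nearest and compound 3 furthest; both gaps lie within the usual scatter, so the three measured compounds cannot be told apart in this assay.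

Compound 4 `COc1ccc(C(=O)/C=C/c2cc(-c3cc(OC)c(OC)c(OC)c3)n[nH]2)cc1OC` has not been measured. It differs from compound 1 in one place: 3,4-dimethoxyphenyl in place of 4-aminophenyl on a carbonyl carbon. Compound 2, which carries the same 3,4-dimethoxyphenyl on its carbonyl carbon, gives 82% in this assay, and compound 3, which carries the 4-aminophenyl there, gives 71%, a pair whose values lie within the scatter of each other.

On that basis the step of a number 5 percentage points higher from compound 1 to compound 4 (within the scatter) is expected to be small and, if anything, toward a weaker effect, but not beyond the scatter. Compound 4 is estimated at 84%, with a range from 70% to 97%.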

Compound 4, a percentage reported as activity, at one concentration (the size of the read-out at that concentration, not a potency): 91%
For compound 4 the middle estimate is 7 percentage points below the measured one; measured number inside the range.
By their numbers in this assay, from the lowest: compounds 3, 1, 2 and 4 (each within the scatter of the next, the first and the last beyond it).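

In this assay, 3,4-dimethoxyphenyl in place of 4-aminophenyl on a carbonyl carbon gives a number 12 percentage points higher from compound 1 to compound 4 (beyond the scatter), a step beyond the scatter and toward a weaker effect. Among the compounds shown here, the same exchange on a different core leaves compound 3 at 71% and compound 2 at 82%, values within the scatter of each other, so a clear effect of this change at this position is seen only on the core of compound 1. No measured evidence accounts for the step.

The compounds shown do not separate the loss of the 4-aminophenyl from the arrival of the 3,4-dimethoxyphenyl. Going by these compounds, an unsubstituted phenyl or a 4-hydroxyphenyl on the same carbonyl carbon would test this, and whether either reaches a stronger effect than compound 1 remains open.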